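Dimethylamino replaces amino on the carbonyl carbon

The source may report more compounds than this note shows. Statements on the series, on what has been measured and on what is new or still open speak of the compounds shown alone.

Compound 1 (`Cc1nc(C(=O)OC2CC2)c(N)c2c1C(=O)N(Cc1ccccc1)C2=O`) and compound 2 (`Cc1nc(C(N)=O)c(N)c2c1C(=O)N(Cc1ccccc1)C2=O`) share a core and differ only in the group on one carbonyl carbon. In a physicochemical assay for solubility, using the shake flask method, in simulated intestinal fluid, measured as kinetic solubility, with a stated time of 2 h, at 25 degrees C, at pH 6.5 (on this read-out lower numbers stand for lower solubility and higher numbers for higher solubility), compound 1 gives 202000 nM. Compound 2 gives < 5000 nM, which is a limit of the assay and not a number. The place of compound 2 is thus known only as the limit of < 5000 nM in this assay, at which 1 of the 2 values shown sits.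

Compound 3 (`Cc1nc(C(=O)N(C)C)c(N)c2c1C(=O)N(Cc1ccccc1)C2=O`) has dimethylamino in place of amino on a carbonyl carbon. Among the measured compounds shown here, the same carbonyl carbon carries the only measured change, an at least 40-fold lower number from compound 1 to compound 2 (1.60 log units; beyond the scatter), a large step beyond the scatter, with amino in place of cyclopropyloxy. For the measured compounds named here, no measurement yet covers dimethylamino. Compound 3 does, however, leave amino behind, and amino is the group on the low side of that step. On the evidence of an at least 40-fold lower number from compound 1 to compound 2 (1.60 log units; beyond the scatter), a higher number in this assay is expected, though a return to the level of compound 1 is not assumed. The expected change is an at least 6.0-fold higher number from compound 2 to compound 3 (0.77 log units; beyond the scatter), and a reading at the same limit remains possible. For compound 3 the estimate is 30000 nM, with an expected range of 5000 nM to 150000 nM.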

Compound 3, solubility: 172000 nM
Beside the measured number, compound 3's estimate is 5.7-fold (0.76 log units) below it, outside the stated range (above it).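

Notes on the carbonyl carbon: the low reading does not follow from having a nitrogen on this carbon, since the position gives a large upward step within a single change of amine. In this assay, dimethylamino in place of amino gives an at least 34-fold higher number from compound 2 to compound 3 (1.53 log units; beyond the scatter). With dimethylamino in place of cyclopropyloxy the step is a 1.2-fold lower number from compound 1 to compound 3 (0.07 log units; within the scatter), which lies within the scatter, so among the three groups shown only amino stands apart from the other two. The reading for compound 2 is a limit and not a number, and the upward step is bounded on one side only because of it: the limit of < 5000 nM in this assay, at which 1 of the 3 values shown sits.

Still open, as far as these compounds go, is whether one methyl group on the nitrogen is enough to leave the low reading behind, which methylamino on the same carbonyl carbon would show, and whether a cyclic amine such as pyrrolidine or morpholine, which also carries no amide hydrogen, reads like dimethylamino. Also open, from the compounds shown here alone, is how a carboxylic acid on this carbon would read, and whether these steps hold when the rest of the shared core changes.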